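The compounds below may be only part of what the source reports. "The series", "measured", "known", "first", "only" and "open" are said of these compounds alone.

Compound 1 `CC(=O)Nc1cc(-c2ccc(OC[C@@H](N)CC(C)C)c(F)c2)ccn1` gives 1.6 nM in an assay on HEK293F cells for inhibition of AP2-associated protein kinase 1 (Homo sapiens), read by Western blot, with a stated time of 3 h; a higher number here means a weaker inhibitor, a lower number a stronger inhibitor; compound 2 `CC(=O)Nc1cc(-c2ccc(OC[C@@H](N)CC(C)C)c(Cl)c2)ccn1` gives 0.2 nM; compound 3 `COC(=O)Nc1cc(-c2cc(C)c(OC[C@@](C)(N)CC(C)C)cn2)ccn1` gives 12 nM.

Among the measured compounds shown here, compound 3 thus has the highest number of the three, with an 8.0-fold lower number from compound 1 to compound 2 (0.90 log units; beyond the scatter) being the only single-point step among them, a step that concerns the halogen on the other aromatic ring and does not bear on what follows. Compound 4 `Cc1cc(-c2ccnc(C(F)F)c2)ncc1OC[C@@](C)(N)CC(C)C` differs from compound 3 by difluoromethyl in place of (methoxycarbonyl)amino on an aromatic carbon. For the measured compounds named here, no measured pair shows the loss of the (methoxycarbonyl)amino group, so the expectation rests on the change alone. The author expects a weakening for compound 4, estimated at 120 nM with a range from 15 nM to 1000 nM, which would mean a step of a 10-fold higher number from compound 3 to compound 4 (1.00 log units; beyond the scatter).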

Compound 4, half-maximal inhibitory concentration: 12 nM
For compound 4 the middle estimate is 10-fold (1.00 log units) above the measured one; measured number below the stated range.
By their numbers in this assay, from the lowest: compound 2; then compound 1; then compounds 3 and 4 (each within the scatter of the next).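

In this assay the swap gives no change at the digits printed from compound 3 to compound 4 (within the scatter), so on this aromatic carbon next to the ring nitrogen, the (methoxycarbonyl)amino group is not required to keep the number. Difluoromethyl, which carries no hydrogen-bond donor or acceptor, serves equally well here, although it is the smaller group by heavy atoms. No supporting measurement explains why the number holds.

Going by these compounds, whether an amine or a plain methyl at this place would also hold the number remains open. So does whether difluoromethyl would do the same on the core of compound 2.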